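This account rests on a few compounds, and the source may have more. Where it says the series, first, only, none or still open, it means among the compounds named here.

Measured so far:
compound 3, `CO[C@@H]1CC=C2N(c3ccccn3)C(=O)C[C@]2(c2ccccc2)O1`: 5100 nM
compound 1, `COc1ccc(N2NC3=CC[C@@H](OC)O[C@@]3(c3ccccc3)CCC2=O)cc1`: 4600 nM
compound 2, `CO[C@@H]1CC=C2NN(c3cc(Cl)cc(Cl)c3)C(=O)CC[C@]2(c2ccccc2)O1`: 7110 nM

In a functional assay on SK-N-SH cells (Homo sapiens) for cytotoxicity, read by sulforhodamine B assay, with a stated time of 48 h (a lower number here means a stronger inhibitor, a higher number a weaker inhibitor), compound 3 gives 5100 nM, the second highest of the three numbers, though its gaps to compound 1 and to compound 2 both fall inside the usual scatter. Compound 4, `CO[C@@H]1CC=C2N(c3c[nH]c4ccccc34)C(=O)C[C@]2(c2ccccc2)O1`, has not yet been measured. It differs from compound 3 in one place: 1H-indol-3-yl in place of pyridin-2-yl on an amide-type nitrogen in a ring. Among the measured compounds shown here, the only measured step that bears on this is a swap of the aryl group on the same kind of nitrogen on a different core, a 1.5-fold higher number from compound 1 to compound 2 (0.19 log units; within the scatter). Because that step was a 1.5-fold higher number from compound 1 to compound 2 (0.19 log units; within the scatter), no step beyond the scatter is expected here, a 1.0-fold lower number from compound 3 to compound 4 (0.01 log units; within the scatter). Compound 4 is therefore estimated at 5000 nM, with a range from 2000 nM to 12500 nM.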

Compound 4, half-maximal inhibitory concentration: 8200 nM
Compound 4: the middle estimate sits 1.6-fold (0.21 log units) below what was measured; the range from low to high includes it.
By their numbers in this assay, from the lowest: compounds 1, 3, 2 and 4 (each within the scatter of the next).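

On the amide-type nitrogen of this five-membered ring, 1H-indol-3-yl in place of pyridin-2-yl adds a second aromatic ring and a hydrogen-bond donor, yet the step stays within the scatter in this assay (a 1.6-fold higher number from compound 3 to compound 4 (0.21 log units; within the scatter)). On this core, then, two quite different aromatic groups on that nitrogen cannot be told apart by this read-out. Nothing available explains this result. Still open, going by these compounds, is whether a non-aromatic group on this nitrogen, such as a longer alkyl chain or an amine, would give a step beyond the scatter.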